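A few compounds are considered here, and "the series" means these few. Any claim that something is new, unique, unknown or untested is made for them only; others in the source may bear on it.

Compound 1 `FC(F)(F)c1ccc(COc2ccc(Nc3ncnc4cc5c(cc34)OCCOCCOCCOCCO5)cc2)cc1`: in a functional assay on MCF7 cells (Homo sapiens) for antiproliferative activity, read by MTT assay, with a stated time of 72 h (a higher number here means a weaker inhibitor, a lower number a stronger inhibitor), compound 1 gives 10000 nM.
Compound 2 `FC(F)(F)c1ccc(COc2cccc(Nc3ncnc4cc5c(cc34)OCCOCCO5)c2)cc1`: compound 2 gives > 100000 nM, which is a limit of the assay and not a number.
Compound 3 `O=[N+]([O-])c1ccc(COc2ccc(Nc3ncnc4cc5c(cc34)OCCOCCOCCOCCO5)cc2)cc1`: compound 3 gives > 100000 nM, likewise a limit of the assay.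

Compound 1 and compound 3 share one core and differ by nitro in place of trifluoromethyl on an aromatic carbon. That change gave an at least 10-fold higher number from compound 1 to compound 3 (1.00 log units; beyond the scatter), a step whose true size is not known because of the limit of > 100000 nM in this assay, at which 2 of the 3 values shown sit.

Compound 2 carries a different core; how its core differs from that of compound 1 is not broken down here. Its value is a limit of the assay.

Compound 4 `O=[N+]([O-])c1ccc(COc2cccc(Nc3ncnc4cc5c(cc34)OCCOCCO5)c2)cc1` stands to compound 2 as compound 3 stands to compound 1: it differs by nitro in place of trifluoromethyl on an aromatic carbon, the same change, at the same place.

Since compound 2 already sits at the limit, and the same change moved compound 1 to the limit by an at least 10-fold higher number from compound 1 to compound 3 (1.00 log units; beyond the scatter), compound 4 is expected to remain at or beyond the limit, an estimated step that the limit leaves unreadable from compound 2 to compound 4. Compound 4 is estimated at 200000 nM, between 100000 nM and 500000 nM, most likely reported only as a limit.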

Compound 4, half-maximal inhibitory concentration: 42400 nM
Estimate against measurement, compound 4: 4.7-fold (0.67 log units) above; measured number outside the range, below it.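

In this assay, nitro in place of trifluoromethyl gave an at least 2.3-fold lower number from compound 2 to compound 4 (0.37 log units; beyond the scatter), so this step runs the opposite way to the one seen on the core of compound 1. The change therefore does not carry over from one core to the other in this series, either in direction or in size: the same change on two cores in this assay, an at least 10-fold higher number (1.00 log units; beyond the scatter) from compound 1 to compound 3 and an at least 2.3-fold lower number (0.37 log units; beyond the scatter) from compound 2 to compound 4, at least 23-fold (1.37 log units) apart, beyond the scatter of two such steps. What this does not show is the true size of either step, because compound 2 and compound 3 each stand at a limit of the assay and not at a number: the limit of > 100000 nM in this assay, at which 2 of the 4 values shown sit.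

The compounds shown leave open which of the differences between the two cores turns the step around. They also leave open whether other groups in the same place, such as a nitrile, an amine or a carboxylic acid, would likewise part ways on the two cores.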